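Moving the chlorine around the benzyl ring of compound 1

The source may report more compounds than this note shows. Statements on the series, on what has been measured and on what is new or still open speak of the compounds shown alone.

Measured compounds, all in a functional assay for agonist activity at Melanocyte-stimulating hormone receptor (Homo sapiens), read by cAMP accumulation; on this read-out lower numbers stand for an effect already at smaller amounts and higher numbers for an effect only at larger amounts of compound:
- compound 1 `CC(C)(C)N1C[C@@H](C(=O)Nc2nccn2Cc2cccc(Cl)c2)[C@H](c2ccc(F)cc2F)C1`: 1270 nM
- compound 2 `CC(C)(C)N1C[C@@H](C(=O)Nc2nccn2Cc2ccc(Cl)cc2)[C@H](c2ccc(F)cc2F)C1`: this value is a limit of the assay, > 10000 nM
- compound 3 `CC(C)(C)N1C[C@@H](C(=O)Nc2nccn2Cc2ccccc2N2CCC(C(=O)O)CC2)[C@H](c2ccc(F)cc2F)C1`: 460 nM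

Compound 1 has the highest number of the two actual numbers in this assay; compound 3 sits below it, and compound 2 gives only a limit (the limit of > 10000 nM in this assay, at which 1 of the 3 values shown sits).

The unmeasured compound 4 `CC(C)(C)N1C[C@@H](C(=O)Nc2nccn2Cc2ccccc2Cl)[C@H](c2ccc(F)cc2F)C1` differs from compound 1 in one place: 2-chlorophenyl in place of 3-chlorophenyl on a saturated chain carbon bound to an aromatic nitrogen.

Among the measured compounds shown here, the one measured step that bears on this place is an at least 7.8-fold higher number from compound 1 to compound 2 (0.89 log units; beyond the scatter), which shows that shifting the chlorine to the 4-chlorophenyl arrangement is not tolerated. For the measured compounds named here, for the 2-chlorophenyl arrangement there is no measured step; the only hint is compound 3, whose value in this assay is lower than that of compound 1 and which also carries its substituent at the corresponding ring position. A step downward is therefore expected, but a small one, given how sharply the other shift cost activity.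

Compound 4 is estimated at 800 nM (range 250 nM to 3000 nM), corresponding to an expected step of a 1.6-fold lower number from compound 1 to compound 4 (0.20 log units; within the scatter).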

Compound 4, half-maximal effective concentration: 1270 nM
Compound 4: middle estimate off by 1.6-fold (0.20 log units), on the low side; measured number inside the range.
By their numbers in this assay, from the lowest: compound 3; then compounds 1 and 4 (each within the scatter of the next). At a limit, above all of these: compound 2.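

In this assay, the chlorine shift from 3-chlorophenyl to 2-chlorophenyl gives no change at the digits printed from compound 1 to compound 4 (within the scatter), so these two arrangements cannot be told apart, whereas the 4-chlorophenyl arrangement is the one that stands off, with an at least 7.8-fold lower number from compound 2 to compound 4 (0.89 log units; beyond the scatter). Going by these compounds, compound 2 gives a limit of the assay and not a number, so the true size of that step stays unknown: the limit of > 10000 nM in this assay, at which 1 of the 4 values shown sits. Compound 3 also keeps its lower number against a plain chloro on the ring, with a 2.8-fold higher number from compound 3 to compound 4 (0.44 log units; beyond the scatter), so the hint it gave is tied to the 4-carboxypiperidin-1-yl group and not to the ring position as such.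

Open, on these data alone, is how other small groups in place of chloro, such as methoxy or a primary amine, would read on this ring. Also open, as far as these compounds go, is whether the carboxylic acid or the piperidine part of the 4-carboxypiperidin-1-yl group carries the difference from chloro, a question that an unsubstituted piperidin-1-yl group would help to separate.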